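A few compounds are considered here, and "the series" means these few. Any claim that something is new, unique, unknown or untested is made for them only; others in the source may bear on it.

Working notes on the series, integrin binding.

Of the compounds shown here, three have been measured in an assay on a protein complex for inhibition of integrin alpha-5/beta-1 (Homo sapiens), read by ELISA; on this read-out lower numbers stand for stronger inhibition and higher numbers for weaker inhibition. Compound 1 `COc1ccnc(NC[C@@H]2C[C@@H](OCC(=O)NC[C@H](NC(=O)C3(C)CCCCC3)C(=O)O)CN2C(=O)OCc2ccccc2)c1` gives 0.8 nM. Compound 2 `COc1ccnc(NC[C@@H]2C[C@@H](OCC(=O)NC[C@H](NS(=O)(=O)c3c(C)cc(C)cc3C)C(=O)O)CN2C(=O)OCc2ccccc2)c1` gives 1.1 nM. Compound 3 `Cc1cc(C)c(S(=O)(=O)N[C@@H](CNC(=O)CO[C@@H]2C[C@@H](CNc3ccccn3)N(C(=O)OCc3ccccc3)C2)C(=O)O)c(C)c1` gives 3.7 nM, the highest number of the three in this assay.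

Compound 2 and compound 1 differ in one place, ((1-methylcyclohexyl)carbonyl in place of (2,4,6-trimethylphenyl)sulfonyl on an amine nitrogen); the step is a 1.4-fold lower number from compound 2 to compound 1 (0.14 log units; within the scatter). Compound 2 and compound 3 differ in the core, (hydrogen in place of methoxy on an aromatic carbon); the step is a 3.4-fold higher number from compound 2 to compound 3 (0.53 log units; beyond the scatter). No single-point step connects compound 1 and compound 3; their values in this assay simply stand as given above.

Compound 4 `CC1(C(=O)N[C@@H](CNC(=O)CO[C@@H]2C[C@@H](CNc3ccccn3)N(C(=O)OCc3ccccc3)C2)C(=O)O)CCCCC1` has not yet been measured. It differs from compound 3 by (1-methylcyclohexyl)carbonyl in place of (2,4,6-trimethylphenyl)sulfonyl on an amine nitrogen. Among the measured compounds shown here, this is the same change as the one made from compound 2 to compound 1, and the place is described in the same words in both cases, so it is the same change on a different core. The two cores differ as described under the difference between compound 2 and compound 3, namely (hydrogen in place of methoxy on an aromatic carbon).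

The step from compound 3 to compound 4 in this assay is estimated at a 1.4-fold lower number from compound 3 to compound 4 (0.14 log units; within the scatter), set beside the measured step of a 1.4-fold lower number from compound 2 to compound 1 (0.14 log units; within the scatter), on which this expectation rests; a second step of the same kind is expected to fall in the same small range. Compound 4 in this assay is therefore expected to give about 2.7 nM, with the estimate spanning from 1.2 nM to 6 nM.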

Compound 4, half-maximal inhibitory concentration: 1.7 nM
Beside the measured number, compound 4's estimate is 1.6-fold (0.20 log units) above it, and the stated range covers the measured number.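

In this assay, (1-methylcyclohexyl)carbonyl in place of (2,4,6-trimethylphenyl)sulfonyl on the amine nitrogen gives a 2.2-fold lower number from compound 3 to compound 4 (0.34 log units; beyond the scatter), and although only this step lies beyond the scatter, it agrees with the step on the methoxy-bearing core: the same change on two cores in this assay, a 1.4-fold lower number (0.14 log units; within the scatter) from compound 2 to compound 1 and a 2.2-fold lower number (0.34 log units; beyond the scatter) from compound 3 to compound 4, 1.6-fold (0.20 log units) apart, within the scatter of two such steps

Hydrogen in place of methoxy on the aromatic carbon, read on the (1-methylcyclohexyl)carbonyl compounds, gives a 2.1-fold higher number from compound 1 to compound 4 (0.33 log units; beyond the scatter), and this change also carries over: the same change on two cores in this assay, a 3.4-fold higher number (0.53 log units; beyond the scatter) from compound 2 to compound 3 and a 2.1-fold higher number (0.33 log units; beyond the scatter) from compound 1 to compound 4, 1.6-fold (0.20 log units) apart, within the scatter of two such steps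

Across these four compounds, each change therefore behaves much the same whichever form the other part takes, but this rests on a single pair of steps per change and does not show that the agreement extends to other groups or other cores, nor does it explain why the steps agree.

Still open, from the compounds shown here alone, is whether the agreement would hold with a chlorine or an amine in place of methoxy on the aromatic carbon, or with a straight-chain acyl group in place of (1-methylcyclohexyl)carbonyl on the amine nitrogen. Also open, going by these compounds, is what an ester or a tetrazole in place of the carboxylic acid would do to either step.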